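The source may report more compounds than this note shows. Statements on the series, on what has been measured and on what is new or still open speak of the compounds shown alone.

Measured so far:
Compound 1, `CCOC(=O)C1=Cc2ccccc2OC1(OCc1cn(-c2cccc(OC)c2)nn1)C(F)(F)F`: in a functional assay on A549 cells (Homo sapiens) for inhibition, read by MTT assay, with a stated time of 24 h (on this read-out higher numbers stand for weaker inhibition and lower numbers for stronger inhibition), compound 1 gives > 150000 nM, which is a limit of the assay and not a number.
Compound 2, `CCOC(=O)C1=Cc2ccccc2OC1(OCc1cn(-c2ccccc2)nn1)C(F)(F)F`: in this assay compound 2 gives > 150000 nM, again a limit of the assay.

Compound 2 therefore stands only at a limit, with no number of its own; both values shown sit at that same limit, (the limit of > 150000 nM in this assay, at which 2 of the 2 values shown sit). Going by the values given here, the one measured step, a step that the two limits leave unreadable from compound 1 to compound 2, cannot be read for size because both ends are limits, so it gives no guide to direction or magnitude.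

Compound 3, `CCOC(=O)C1=Cc2ccccc2OC1(OCc1cn(-c2ccc(F)c([N+](=O)[O-])c2)nn1)C(F)(F)F`, differs from compound 2 by 4-fluoro-3-nitrophenyl in place of phenyl on an aromatic nitrogen. Among the compounds with values here, no measured step bears on this change, and nothing in the data points to a step beyond the scatter in this assay in either direction. The step expected is a step that the limit leaves unreadable from compound 2 to compound 3. Compound 3 is therefore estimated at 200000 nM, with a range from 80000 nM to 500000 nM, most likely again reported only as a limit.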

Compound 3, half-maximal inhibitory concentration: 11900 nM
For compound 3 the middle estimate is 17-fold (1.23 log units) above the measured one, outside the stated range (below it).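

In this assay, going by these compounds alone, the group on the aromatic nitrogen of the five-membered aromatic ring proves able to shift the read-out, which the earlier compounds could not show. Putting 4-fluoro-3-nitrophenyl in place of phenyl gives a large step (an at least 12-fold lower number from compound 2 to compound 3 (1.10 log units; beyond the scatter)), and putting it in place of 3-methoxyphenyl gives another (an at least 12-fold lower number from compound 1 to compound 3 (1.10 log units; beyond the scatter)). Compound 3 is the only compound shown with a number of its own, and the other two stay at a limit, so the step between them still cannot be read and these two steps are known only as minimum sizes: (the limit of > 150000 nM in this assay, at which 2 of the 3 values shown sit).

The fluorine and the nitro group enter together, so the compounds shown leave open how much of the step belongs to each. They also leave open how an amine or a carboxylic acid on the phenyl ring would read in this assay.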